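The source may report more compounds than this note shows. Statements on the series, on what has been measured and on what is new or still open speak of the compounds shown alone.

Compound 1, whose structure is `CC[C@H](C)[C@@H]1C(=O)N[C@H](C2Cc3ccccc3C2)C(=O)N1[C@@H](C(=O)N1CCOCC1)c1ccc(C)nc1`, was tested in an in vitro ADME assay on microsomes from liver (Rattus norvegicus) for metabolic stability (a higher number here means faster removal of the compound, a lower number slower removal), where compound 1 gives 1 mL.min-1.g-1. Compound 2, with the structure `CCC(CC)[C@@H]1C(=O)N[C@H](C2Cc3ccccc3C2)C(=O)N1[C@@H](C(=O)N1CCOCC1)c1ccc(C)nc1C`, gives 1 mL.min-1.g-1 in this assay. Compound 1 thus stands level with compound 2 at the digits shown; the two values lie within the scatter of this assay, so nothing separates them. Compound 3, with the structure `CC[C@@H](C)[C@@H]1C(=O)N[C@H](C2Cc3ccccc3C2)C(=O)N1[C@@H](C(=O)N1CCOCC1)c1ccc(C)nc1`, has not yet been measured. Its difference from compound 1 is counted as follows: the two compounds have the same atoms and bonds and differ only in configuration as drawn: 1 of 4 stereo elements differ; a stereocentre at a saturated chain carbon is drawn S in compound 1 and R in compound 3. Among the measured compounds shown here, no step between two measured compounds is available here, so the only guide is the low clearance shared by compound 1 and compound 2. For a change of configuration alone, a step in this assay no larger than the scatter is expected, in either direction. Compound 3 is therefore expected to give about 1.5 mL.min-1.g-1, within a range from 0.7 mL.min-1.g-1 to 4 mL.min-1.g-1. This estimate means an expected step of a 1.5-fold higher number from compound 1 to compound 3 (0.18 log units; within the scatter).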

Compound 3, intrinsic clearance in microsomes: 1 mL.min-1.g-1
Estimate against measurement, compound 3: 1.5-fold (0.18 log units) above, and the stated range covers the measured number.
By their numbers in this assay, from the lowest: compounds 1, 2 and 3 (each within the scatter of the next).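

Changing the configuration at this saturated chain carbon gives, in this assay, no change at the digits printed from compound 1 to compound 3 (within the scatter). Among the compounds shown here, the earlier pair, compound 1 and compound 2, differs in more than one place, so this is the first comparison here that isolates a single position, and it can be read cleanly because only one feature varies: the fact that compounds 1 and 3 differ only in the configuration as drawn. For this pair, then, whether the stereocentre is drawn S or R leaves the intrinsic clearance unchanged at the digits printed, and neither form can be preferred on this measurement.

As far as these compounds go, the other stereo elements stay the same in this pair, so their configurations remain untested by this step. The compounds shown also do not tell how the clearance would respond if a longer chain, an amine or a carboxylic acid stood at this position.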